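Swapping Chloro for Methyl on the Benzoyl Ring

The source may report more compounds than this note shows. Statements on the series, on what has been measured and on what is new or still open speak of the compounds shown alone.

Compound 3, `Cn1cnc(C(=O)NNC(=O)COc2c(F)cc(C(=O)c3ccc(Cl)cc3)cc2Cl)c1`, was tested in a functional assay on MCF7 cells (Homo sapiens) for cytotoxicity, read by MTT assay, with a stated time of 48 h (a higher number here means a weaker inhibitor, a lower number a stronger inhibitor), and gave 43100 nM, the second highest of the three numbers recorded. Its nearest neighbour is compound 2, `Cn1cnc(C(=O)NNC(=O)COc2c(F)cc(C(=O)c3ccc(F)cc3)cc2Cl)c1`, which in this assay gives 45100 nM; compound 1, `Cc1ccc(C(=O)c2cc(F)c(OCC(=O)NNC(=O)c3ccc(=O)oc3)c(Cl)c2)cc1`, gives 23600 nM, and both of these lie within the scatter of the number for compound 3. Going by the values given here, the single step among the measured compounds, a 1.0-fold lower number from compound 2 to compound 3 (0.02 log units; within the scatter), exchanged one halogen for another on an aromatic carbon and did not move the number beyond the scatter.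

Compound 4, `Cc1ccc(C(=O)c2cc(F)c(OCC(=O)NNC(=O)c3cn(C)cn3)c(Cl)c2)cc1`, differs from compound 3 in one place: methyl in place of chloro on an aromatic carbon. Among the compounds with values here, no measured pair shows this exact exchange. Within the data shown here, the one measured step, a 1.0-fold lower number from compound 2 to compound 3 (0.02 log units; within the scatter), also altered a small group on an aromatic carbon and stayed within the scatter, so no change beyond the scatter is expected here either. The expected step is a 1.1-fold lower number from compound 3 to compound 4 (0.03 log units; within the scatter). Compound 4 is estimated to give 40000 nM in this assay, with a range from 18000 nM to 90000 nM.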

Compound 4, half-maximal inhibitory concentration: 9800 nM
Compound 4: middle estimate off by 4.1-fold (0.61 log units), on the high side; the whole stated range lies above it.
By their numbers in this assay, from the lowest: compound 4; then compounds 1, 3 and 2 (each within the scatter of the next).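

In this assay the change from 4-chlorophenyl to 4-methylphenyl gives a 4.4-fold lower number from compound 3 to compound 4 (0.64 log units; beyond the scatter) and methyl in place of fluoro at the same place gives a 4.6-fold lower number from compound 2 to compound 4 (0.66 log units; beyond the scatter) so this position does respond, even though exchanging one halogen for the other gave only a 1.0-fold lower number from compound 2 to compound 3 (0.02 log units; within the scatter) and stayed within the scatter. With the methyl kept, the other end of the molecule also counts: the five-membered aromatic ring with 2 hetero atoms, in place of the six-membered ring with 1 hetero atom, gives a 2.4-fold lower number from compound 1 to compound 4 (0.38 log units; beyond the scatter) and this too lies beyond the scatter. No measurement here explains why methyl parts from the two halogens.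

From the compounds shown here alone, whether an ethyl, a methoxy or an amine at this position would follow methyl or the halogens remains open. Compound 1 has no chloro or fluoro partner among these compounds, so it is also open whether the methyl step carries over to its six-membered ring.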